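Chain extension of a cinnamate ester: propyl to butyl

A few compounds are considered here, and "the series" means these few. Any claim that something is new, unique, unknown or untested is made for them only; others in the source may bear on it.

Compound 2 `CCCOC(=O)/C=C/c1ccccc1` stands lowest of the two compounds measured in a functional assay on the whole organism for inhibition, with Brassica rapa subsp. chinensis as the target, with a stated time of 3 days, tested at 100 ppm (on this read-out lower numbers stand for less inhibition of growth and higher numbers for more inhibition of growth at the one concentration tested), where compound 2 gives 7%. Its nearest neighbour is compound 1 `CCC(C)OC(=O)/C=C/c1ccccc1`, which in this assay gives 20%; the step of a number 13 percentage points lower from compound 1 to compound 2 (beyond the scatter) is modest, yet beyond the scatter. Compound 3 `CCCCOC(=O)/C=C/c1ccccc1` has not been measured. It differs from compound 2 by methyl in place of hydrogen on a saturated chain carbon, three bonds along the chain from an oxygen next to a carbonyl group. For the measured compounds named here, the one measured step concerns a methyl in a different place, on the saturated chain carbon bound to the oxygen next to the carbonyl group, so it bears on the present change only loosely; it shows that a single methyl in this ester group can move the number by a modest amount. A small rise or no change beyond the scatter is therefore expected in this assay for compound 3, estimated at 14% within 0% to 30%, a step of a number 7 percentage points higher from compound 2 to compound 3 (within the scatter).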

Compound 3, percent growth inhibition at one concentration: 0%
The estimate for compound 3 lay 14 percentage points above the measured number, and the stated range covers the measured number.
By their numbers in this assay, from the lowest: compounds 3 and 2 (each within the scatter of the next); then compound 1.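

In this assay, the added methyl at this position, on a saturated chain carbon three bonds along the chain from an oxygen next to a carbonyl group, gives a number 7 percentage points lower from compound 2 to compound 3 (within the scatter), so taking propyl to butyl here produces no change beyond the scatter. Butyl in place of sec-butyl gives a number 20 percentage points lower from compound 1 to compound 3 (beyond the scatter), which leaves compound 1, with its branched ester group, apart from both straight-chain esters. Nothing available explains either step.

As far as these compounds go, whether a longer chain such as pentyl or hexyl would stay within the scatter of compound 3 remains open. So does the outcome for a carboxylic acid or an amide in place of the ester, and for a branch further along the chain.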